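A few compounds are considered here, and "the series" means these few. Any claim that something is new, unique, unknown or untested is made for them only; others in the source may bear on it.

Compound 1 `Nn1c(SCc2ccccc2)nnc1-c1c[nH]c2ccccc12` is the point of departure: in a functional assay on KG-1a cells (Homo sapiens) for cytotoxicity, with a stated time of 24 h (a higher number here means a weaker inhibitor, a lower number a stronger inhibitor), compound 1 gives 17200 nM. Compound 2 `Nn1c(SCc2ccccc2[N+](=O)[O-])nnc1-c1c[nH]c2ccccc12` gives 20800 nM in this assay, and the step of a 1.2-fold higher number from compound 1 to compound 2 (0.08 log units; within the scatter) stays within the scatter, so compound 1 stands together with compound 2 rather than apart from it. Compound 3 `Nn1c(SCc2cccc([N+](=O)[O-])c2)nnc1-c1c[nH]c2ccccc12` differs from compound 1 by nitro in place of hydrogen on an aromatic carbon. Within the data shown here, the only measured step that bears on this change is the one from compound 1 to compound 2, in which a nitro group also entered the same six-membered aromatic ring of carbon only, and that step was within the scatter; no step beyond the scatter is therefore expected for compound 3 in this assay. Compound 3 is estimated at 18000 nM, between 9000 nM and 36000 nM, which means an expected step of a 1.0-fold higher number from compound 1 to compound 3 (0.02 log units; within the scatter).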

Compound 3, half-maximal inhibitory concentration: 650 nM
For compound 3 the middle estimate is 28-fold (1.44 log units) above the measured one, and the stated range ends above it.
By their numbers in this assay, from the lowest: compound 3; then compounds 1 and 2 (each within the scatter of the next).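

Nitro meta to a large group brings a 26-fold lower number from compound 1 to compound 3 (1.42 log units; beyond the scatter) in this assay and thus shows a large step that compound 2 did not show. The same group therefore counts very differently according to where it stands on this ring, since compound 2 gives 20800 nM and compound 3 gives 650 nM in the same test. Nothing at hand explains this difference.

On these data alone, whether an amine or a carboxylic acid at the place held by nitro in compound 3 would bring a similar step remains open. So does whether nitro at this place would matter on a longer chain.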